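The compounds below may be only part of what the source reports. "The series", "measured", "known", "first", "only" and "open" are said of these compounds alone.

Compound 1 `CC(C)(C)NCC(=O)Nc1nc2ccc(Cl)cc2s1`: 100 mg/kg
Compound 2 `O=C(Cn1ccnc1)Nc1nc2ccc(Cl)cc2s1`: 30 mg/kg

In a functional assay on the whole organism with Mus musculus as the target, in the maximal electroshock model, with a stated time of 4 h (a higher number here means that more compound is needed for the effect, a lower number that less compound is needed), compound 1 gives the highest of the two numbers; its nearest neighbour is compound 2, with a 3.3-fold lower number from compound 1 to compound 2 (0.52 log units; beyond the scatter). Compound 3 `O=C(CNc1ccc(F)cc1)Nc1nc2ccc(Cl)cc2s1` keeps the shared core; the change from compound 1 is 4-fluorophenyl in place of tert-butyl on an amine nitrogen. For the measured compounds named here, only one measured step bears on this, and it is a loose guide, since it is a change at a different place: it was modest, and in the lowering direction. A modest lowering is therefore expected, a 2.0-fold lower number from compound 1 to compound 3 (0.30 log units; within the scatter). For compound 3 in this assay the estimate is 50 mg/kg, range 20 mg/kg to 150 mg/kg.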

Compound 3, minimum effective dose: 100 mg/kg
Compound 3: the middle estimate sits 2.0-fold (0.30 log units) below what was measured; low and high end bracket the measured number.
By their numbers in this assay, from the lowest: compound 2; then compounds 1 and 3 (each within the scatter of the next).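

In this assay, 4-fluorophenyl in place of tert-butyl on the amine nitrogen gives no change at the digits printed from compound 1 to compound 3 (within the scatter). At this position, a group with one six-membered aromatic ring and 7 heavy atoms therefore reads the same as a ringless group with 4 heavy atoms, so neither ring nor group size separates this pair. No available evidence bears on this result.

Open, as far as these compounds go, is whether plain phenyl reads the same without the fluorine. Also open, from the compounds shown here alone, is how a morpholine or a carboxylic acid would read on the same saturated chain carbon.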